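Swapping the Aryl Group of Compound 3: An Expected Loss

This account rests on a few compounds, and the source may have more. Where it says the series, first, only, none or still open, it means among the compounds named here.

Three compounds have been measured in a functional assay on HCT-116 cells (Homo sapiens) for antiproliferative activity, read by MTT assay; on this read-out higher numbers stand for weaker inhibition and lower numbers for stronger inhibition:

compound 1 `Cn1c(=O)c(=O)n(C2CCCC2)c2nc(N/N=C/c3ccc(O)cc3)ncc21` gives 72500 nM
compound 2 `Cn1c(=O)c(=O)n(C2CCCC2)c2nc(N/N=C/c3ccc(S(C)(=O)=O)cc3)ncc21` gives 86600 nM
compound 3 `Cc1cc(C)c(/C=N/Nc2ncc3c(n2)n(C2CCCC2)c(=O)c(=O)n3C)c(C)c1` gives 7920 nM

Compound 3 stands lowest of the three, which on this read-out means the strongest inhibition: a 9.2-fold lower number from compound 1 to compound 3 (0.96 log units; beyond the scatter) and an 11-fold lower number from compound 2 to compound 3 (1.04 log units; beyond the scatter). Between the two weaker compounds the difference is small: a 1.2-fold higher number from compound 1 to compound 2 (0.08 log units; within the scatter).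

Compound 4 `CSc1ccc(/C=N/Nc2ncc3c(n2)n(C2CCCC2)c(=O)c(=O)n3C)cc1` has not been measured. It differs from compound 3 in one place: 4-(methylsulfanyl)phenyl in place of 2,4,6-trimethylphenyl on a carbon with a double bond to nitrogen.

Among the measured compounds shown here, two measured steps bear directly on this change. Both compound 1 and compound 2 carry a phenyl ring bearing a single substituent at the 4-position, and each sits far above compound 3, as a 9.2-fold lower number from compound 1 to compound 3 (0.96 log units; beyond the scatter) and an 11-fold lower number from compound 2 to compound 3 (1.04 log units; beyond the scatter) show. The step of a 1.2-fold higher number from compound 1 to compound 2 (0.08 log units; within the scatter) further shows that exchanging one 4-substituent for another left the number essentially unchanged. On these data alone, compound 4 returns to a 4-substituted phenyl, so the step in this assay is expected to run back toward higher numbers, roughly undoing the gain seen for compound 3, though the new substituent is untested and some spread must be allowed.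

Compound 4 is therefore expected to give about 40000 nM in this assay, within a range of 12000 nM to 120000 nM, an estimated step of a 5.1-fold higher number from compound 3 to compound 4 (0.70 log units; beyond the scatter).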

Compound 4, half-maximal inhibitory concentration: 9010 nM
Compound 4: middle estimate off by 4.4-fold (0.65 log units), on the high side, outside the stated range (below it).
By their numbers in this assay, from the lowest: compounds 3 and 4 (each within the scatter of the next); then compounds 1 and 2 (each within the scatter of the next).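

In this assay, the result shows that the 2,4,6-trimethylphenyl group is not needed for the low number, since 4-(methylsulfanyl)phenyl in the same place on the carbon with a double bond to nitrogen gives a number that cannot be told apart from it (a 1.1-fold higher number from compound 3 to compound 4 (0.06 log units; within the scatter)). It also shows that a single group on the phenyl ring can matter a great deal, which the earlier exchange of hydroxy for methylsulfonyl did not reveal (a 1.2-fold higher number from compound 1 to compound 2 (0.08 log units; within the scatter)): methylsulfanyl in place of methylsulfonyl gives a 9.6-fold lower number from compound 2 to compound 4 (0.98 log units; beyond the scatter), and methylsulfanyl in place of hydroxy gives an 8.0-fold lower number from compound 1 to compound 4 (0.91 log units; beyond the scatter). Nothing measured here explains why methylsulfanyl stands apart from the other two groups.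

The compounds shown leave open how an amine, a carboxylic acid or a longer sulfur-bearing chain such as ethylsulfanyl would fare in place of methylsulfanyl on that aromatic carbon. They also leave open whether compound 3 and compound 4 would stay this close on other kinds of cells.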